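The source may hold more compounds than are shown below. What is called first, only, known or untested is meant among the compounds shown, and "the series" means these compounds.

Compound 3 `COc1ccc2nc(C)cc(OCC(=O)Nc3cc(C)ccc3C)c2c1` shares its core with compound 1 `COc1ccc2nc(C)cc(OCC(=O)Nc3cc(C)cc(C)c3)c2c1` and compound 2 `COc1ccc2nc(C)cc(OCC(=O)Nc3cccc(C)c3)c2c1`. In an ADME assay on microsomes from liver (Mus musculus) for metabolic stability, read by LC-MS, using NADPH, with a stated time of 30 min, tested at 0.5 uM (on this read-out higher numbers stand for a longer-lived compound and lower numbers for a shorter-lived compound), compound 3 gives < 0.0834 h, which is a limit of the assay rather than a number. Compound 1 gives < 0.0834 h, also a limit. Compound 2 gives < 0.0834 h, again a limit. The steps a step that the two limits leave unreadable from compound 1 to compound 3, a step that the two limits leave unreadable from compound 2 to compound 3 and a step that the two limits leave unreadable from compound 1 to compound 2 therefore cannot be read, as the limit of < 0.0834 h in this assay, at which 3 of the 3 values shown sit, shows. Compound 4 `COc1ccc2nc(C)cc(OCC(=O)Nc3cc(C)c(F)c(C)c3)c2c1` differs from compound 3 by 4-fluoro-3,5-dimethylphenyl in place of 2,5-dimethylphenyl on an amide-type nitrogen. Going by the values given here, no measured step gives a readable size for such a change, and every value so far sits at the same limit, so compound 4 is expected to give 0.05 h, between 0.02 h and 0.15 h, most likely reported again as a limit. The expected step that the limit leaves unreadable from compound 3 to compound 4 thus rests on no readable measured counterpart.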

Compound 4, half-life: < 0.0834 h
Compound 4: a limit, no number (the forecaster's own chance of this, stated with the estimate: 75%); the middle value does not contradict the limit.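

Compound 4 also gives a limit rather than a number, so its steps from compound 1, compound 2 and compound 3 cannot be read: the limit of < 0.0834 h in this assay, at which 4 of the 4 values shown sit. The compounds shown leave open whether any change in the group on the amide-type nitrogen alters the half-life at all.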